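This account rests on a few compounds, and the source may have more. Where it says the series, first, only, none or still open, it means among the compounds named here.

In an ADME assay on BHK cells (Mesocricetus auratus) for cytotoxicity, read by MTT assay, with a stated time of 96 h (a higher number here means that more compound is tolerated, a lower number that less compound is tolerated), three compounds that share one core have been measured. Compound 1 `Fc1ccc(-c2nc3cc(C(F)(F)F)ccc3[nH]2)cc1` gives 25000 nM. Compound 2 `CC(=O)Nc1ccc(-c2nc3cc(C(F)(F)F)ccc3[nH]2)cc1` gives 53000 nM, and the change from compound 1 to compound 2 is a 2.1-fold higher number from compound 1 to compound 2 (0.33 log units; beyond the scatter). Compound 3 `Oc1ccc(-c2nc3cc(C(F)(F)F)ccc3[nH]2)cc1` gives only a limit of the assay, > 100000 nM, and no number. Compound 3 therefore stands at the limit of > 100000 nM in this assay, at which 1 of the 3 values shown sits, so that the step of an at least 4.0-fold higher number from compound 1 to compound 3 (0.60 log units; beyond the scatter) and the step of an at least 1.8-fold higher number from compound 2 to compound 3 (0.27 log units; that floor lies within the scatter) are both floors rather than exact sizes.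

Compound 4 `CCN(CC)CC(=O)Nc1ccc(-c2nc3cc(C(F)(F)F)ccc3[nH]2)cc1` differs from compound 3 in one place: (((diethylamino)methyl)carbonyl)amino in place of hydroxy on an aromatic carbon. The measured steps that bear on this change are the ones involving the acetamido of compound 2, since compound 4 also carries an amide on that carbon. The step from compound 2 to compound 3 is at least modest and was not resolved beyond the scatter, while the step from compound 1 to compound 2 was modest. Going from the hydroxy of compound 3 back to an amide is thus expected to move the number down by a modest amount at most. The estimated step is an at least 1.4-fold lower number from compound 3 to compound 4 (0.15 log units; that floor lies within the scatter). Compound 4 is accordingly estimated at 70000 nM, with a range from 30000 nM to 160000 nM.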

Compound 4, half-maximal cytotoxic concentration: 23000 nM
The estimate for compound 4 lay 3.0-fold (0.48 log units) above the measured number, outside the stated range (below it).
By their numbers in this assay, from the lowest: compounds 4 and 1 (each within the scatter of the next); then compound 2. At a limit, above all of these: compound 3.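

In this assay, the (((diethylamino)methyl)carbonyl)amino group on this aromatic carbon gives an at least 4.3-fold lower number from compound 3 to compound 4 (0.63 log units; beyond the scatter), and this is only a floor, as compound 3 stands at a limit of the assay: the limit of > 100000 nM in this assay, at which 1 of the 4 values shown sits. The earlier compounds shown here showed only that replacing fluoro with acetamido or hydroxy here raised the number, whereas diethylamino in place of hydrogen on the saturated chain carbon bound to the carbonyl carbon gives a 2.3-fold lower number from compound 2 to compound 4 (0.36 log units; beyond the scatter), so a change further out on the amide can lower it by a modest amount. With a 1.1-fold lower number from compound 1 to compound 4 (0.04 log units; within the scatter), compound 4 and compound 1 cannot be told apart here, so the larger amide keeps none of the margin that acetamido held over fluoro.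

Going by these compounds, it remains open whether the diethylamino group itself accounts for the step or whether a plain alkyl chain of similar length, a smaller dimethylamino group, or a carboxylic acid at the chain end would do the same. How far the hydroxy of compound 3 truly stands from either amide also stays unresolved, and the steps to compound 3 cannot be read as exact sizes.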